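Mirror Images and a Fluoro-for-Phenyl Swap

A few compounds are considered here, and "the series" means these few. Any claim that something is new, unique, unknown or untested is made for them only; others in the source may bear on it.

Compound 1 `O[C@@H]1[C@@H](O)CN[C@H]1c1ccc(-c2ccccc2)cc1`: 0%
Compound 2 `O[C@@H]1[C@@H](O)CN[C@H]1c1ccc(F)cc1`: 1.2%
Compound 3 `O[C@H]1[C@H](O)CN[C@@H]1c1ccc(-c2ccccc2)cc1`: 0%

Three compounds were measured in an assay on isolated protein for inhibition of alpha-mannosidase (Canavalia ensiformis), read by spectrophotometry, tested at 1000 uM; a higher number here means more inhibition at the concentration tested (going by the name of the read-out), a lower number less inhibition. Compound 1 and compound 3 share every atom and bond (the two compounds have the same atoms and bonds and differ only in configuration as drawn: 3 of 3 stereo elements differ (all stereocentres are inverted: mirror images); a stereocentre at a saturated ring carbon is drawn S in compound 1 and R in compound 3; a stereocentre at a saturated ring carbon is drawn S in compound 1 and R in compound 3; a stereocentre at a saturated ring carbon is drawn S in compound 1 and R in compound 3), a fact worth holding onto (the fact that compounds 1 and 3 differ only in the configuration as drawn), and the result is no change at the digits printed from compound 1 to compound 3 (within the scatter). Exchanging one group on compound 1 gives compound 2 (fluoro in place of phenyl on an aromatic carbon), and the result is a number 1.2 percentage points higher from compound 1 to compound 2 (within the scatter); in this assay compound 2 gives 1.2%. All three numbers sit together near the bottom of the scale.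

Compound 4 `O[C@H]1[C@H](O)CN[C@@H]1c1ccc(F)cc1` has not been measured. It stands to compound 3 as compound 2 stands to compound 1 (fluoro in place of phenyl on an aromatic carbon), the same change on the mirror-image core. Given that the measured step was a number 1.2 percentage points higher from compound 1 to compound 2 (within the scatter), the step from compound 3 to compound 4 is expected to be a number 1 percentage points higher from compound 3 to compound 4 (within the scatter), since the same change left the number within the scatter in the measured pair. Compound 4 is therefore estimated at 1%, between 0% and 8%.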

Compound 4, a percentage reported as inhibition, at one concentration (the size of the read-out at that concentration, not a potency): 0.8%
Compound 4: the middle estimate sits 0.2 percentage points above what was measured; measured number inside the range.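

In this assay, fluoro in place of phenyl on the mirror-image core gave a number 0.8 percentage points higher from compound 3 to compound 4 (within the scatter), and the two cores agree on this change: the same change on two cores in this assay, a number 1.2 percentage points higher (within the scatter) from compound 1 to compound 2 and a number 0.8 percentage points higher (within the scatter) from compound 3 to compound 4, 0.4 percentage points apart, within the scatter of two such steps. Inverting all the stereocentres of the fluoro compound gave a number 0.4 percentage points lower from compound 2 to compound 4 (within the scatter), matching the result for the phenyl pair: the fact that compounds 2 and 4 differ only in the configuration as drawn. Among these compounds, with all four numbers near the bottom of the scale, this shows only that the change leaves the number within the scatter on both cores, not how it would carry over where inhibition is clearly readable.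

On these data alone, whether another group on that aromatic carbon, such as an amine, a carboxylic acid or a longer chain, would raise the number remains open. As far as these compounds go, how these four compounds behave against any other enzyme also remains open.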